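Swapping a basic tail for a triazole diol

This account rests on a few compounds, and the source may have more. Where it says the series, first, only, none or still open, it means among the compounds named here.

Of the compounds shown here, three sharing one core have been measured in a functional assay on A-375 cells (Homo sapiens) for cytotoxicity, read by MTT assay, with a stated time of 72 h; on this read-out lower numbers stand for stronger inhibition and higher numbers for weaker inhibition. Compound 1 `CN(C)CCCCCn1c2c(c3ccccc31)C(=O)c1c[n+]([O-])c3ccccc3c1C2=O` gives 560 nM. Compound 2 `O=C1c2c[n+]([O-])c3ccccc3c2C(=O)c2c1c1ccccc1n2CCN1CCCC1` gives 430 nM, and compound 3 `O=C1c2c[n+]([O-])c3ccccc3c2C(=O)c2c1c1ccccc1n2CCN1CCCCC1` gives 180 nM. Compound 2 therefore holds the second highest number of the three: its gap to compound 1 is within the scatter, while the step of a 2.4-fold lower number from compound 2 to compound 3 (0.38 log units; beyond the scatter) lies beyond it.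

Compound 4 `O=C1c2c[n+]([O-])c3ccccc3c2C(=O)c2c1c1ccccc1n2Cc1cn(C[C@@H](O)CO)nn1` differs from compound 2 in one place: 1-(2,3-dihydroxypropyl)-1H-1,2,3-triazol-4-yl in place of (pyrrolidin-1-yl)methyl on a saturated chain carbon bound to an aromatic nitrogen. The measured steps, a 1.3-fold lower number from compound 1 to compound 2 (0.11 log units; within the scatter), a 3.1-fold lower number from compound 1 to compound 3 (0.49 log units; beyond the scatter) and a 2.4-fold lower number from compound 2 to compound 3 (0.38 log units; beyond the scatter), each exchange one saturated nitrogen-containing group for another of similar size and move the numbers at most modestly. None of them involves a triazole or a dihydroxypropyl group, so they offer no direct guide to this change; they show only that the tail two bonds from the aromatic nitrogen can shift the number noticeably. Since the incoming group is larger and unlike anything measured, the step from compound 2 to compound 4 is expected to be a moderate rise, a 3.5-fold higher number from compound 2 to compound 4 (0.54 log units; beyond the scatter), with wide uncertainty. Compound 4 is accordingly estimated at 1500 nM, within a range from 400 nM to 6000 nM.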

Compound 4, half-maximal inhibitory concentration: 140 nM
For compound 4 the middle estimate is 11-fold (1.03 log units) above the measured one; measured number below the stated range.
By their numbers in this assay, from the lowest: compounds 4 and 3 (each within the scatter of the next); then compounds 2 and 1 (each within the scatter of the next).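

In this assay, the saturated ring amine of compound 2 gives way to a triazole carrying a diol, and the result is a 3.1-fold lower number from compound 2 to compound 4 (0.49 log units; beyond the scatter). This shows that, on a saturated chain carbon bound to an aromatic nitrogen, the number can fall without a (pyrrolidin-1-yl)methyl group in place, even though the entering group is larger, with 10 heavy atoms against 6. The piperidine-bearing tail offers no clear edge over the triazole diol, with a gap of a 1.3-fold lower number from compound 3 to compound 4 (0.11 log units; within the scatter), so those two tails cannot be ranked, whereas the long amine chain gives a 4.0-fold lower number from compound 1 to compound 4 (0.60 log units; beyond the scatter).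

No measurement shown accounts for this drop in the number. On these data alone, it also remains open whether the triazole ring, the diol or the two together matter, which could be tested by comparing compound 4 with a triazole bearing a simple methyl group, a triazole bearing a propyl chain with a single hydroxyl group or a triazole bearing a carboxylic acid, and by comparing it with the mirror-image form of its diol.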